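Ester Chain Length and Growth Inhibition

The compounds below may be only part of what the source reports. "The series", "measured", "known", "first", "only" and "open" are said of these compounds alone.

Compound 1, `CCCCCCC(ON1C(=O)c2ccccc2C1=O)C(=O)OCC`, gives 0% in a functional assay on the whole organism for inhibition, with Lepidium sativum as the target, tested at 1 ppm; a higher number here means more inhibition of growth at the concentration tested, a lower number less inhibition of growth.
Compound 2, `CCCOC(=O)C(C)ON1C(=O)c2ccccc2C1=O`, gives 64% in this assay.
Compound 3, `CCCCOC(=O)C(C)ON1C(=O)c2ccccc2C1=O`, gives 59% in this assay.

Compound 3 stands second highest of these three values, close to compound 2 and well above compound 1. Compound 4, `CCOC(=O)C(C)ON1C(=O)c2ccccc2C1=O`, differs from compound 3 by hydrogen in place of ethyl on a saturated chain carbon, two bonds along the chain from an oxygen next to a carbonyl group. Going by the values given here, the only measured step that bears on this change is a number 5 percentage points lower from compound 2 to compound 3 (within the scatter), a step within the scatter. Among the compounds with values here, no measured step covers the change from butyl to ethyl directly, and compound 1 differs in another place. The expected step, a number 1 percentage points higher from compound 3 to compound 4 (within the scatter), is therefore none beyond the scatter in this assay. Compound 4 is estimated at 60%, with a range from 40% to 80%.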

Compound 4, percent growth inhibition at one concentration: 68%
Beside the measured number, compound 4's estimate is 8 percentage points below it; the range from low to high includes it.
By their numbers in this assay, from the lowest: compound 1; then compounds 3, 2 and 4 (each within the scatter of the next).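

At this position, butyl to ethyl gives a number 9 percentage points higher from compound 3 to compound 4 (within the scatter), and hydrogen in place of methyl on the same carbon gives a number 4 percentage points higher from compound 2 to compound 4 (within the scatter), so this assay does not separate these three ester chains. The other chain counts for far more: hydrogen in place of pentyl, two bonds along the chain from a carbonyl carbon and an oxygen on an unsaturated carbon, gives a number 68 percentage points higher from compound 1 to compound 4 (beyond the scatter). Nothing available accounts for either result. Going by these compounds, whether a methyl ester, a longer ester chain or a carboxylic acid would keep this inhibition stays open. So does the effect of a propyl chain at the other place, whose length between methyl and hexyl remains unresolved.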